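Adding a methyl group to compound 2

The source may report more compounds than this note shows. Statements on the series, on what has been measured and on what is new or still open speak of the compounds shown alone.

Of the compounds shown here, three with a shared core have been measured in an ADME assay on microsomes from liver (Homo sapiens) for metabolic stability, using NADPH, with a stated time of 40 min, tested at 2 uM (a higher number here means that the compound lasts longer, a lower number that the compound disappears faster), so far. Compound 1 `Fc1ccc2c(-c3ccc4ccccc4n3)c[nH]c2c1Cl` gives 0.183 h there, compound 2 `Clc1cccc2c(-c3ccc4ccccc4n3)c[nH]c12` gives 0.283 h there and compound 3 `Cc1cccc2c(-c3ccc4ccccc4n3)c[nH]c12` gives 0.35 h there. Compound 2 thus holds the middle place among these numbers, but both of its steps are small. Compound 4 `Cc1cc(Cl)c2[nH]cc(-c3ccc4ccccc4n3)c2c1` differs from compound 2 by a single change, (methyl in place of hydrogen on an aromatic carbon), which is methyl in place of hydrogen on an aromatic carbon, meta to a chloro group. For the measured compounds named here, two measured steps bear on this, namely a 1.5-fold higher number from compound 1 to compound 2 (0.19 log units; within the scatter) and a 1.2-fold higher number from compound 2 to compound 3 (0.09 log units; within the scatter) as well. Neither alters the carbon that changes here, although the second also brings in a methyl, so both are only indirect guides. Both stayed within the scatter, so no clear move in either direction is expected. The expected result is a 1.0-fold lower number from compound 2 to compound 4 (0.00 log units; within the scatter) and thus no step beyond the scatter. For compound 4 the estimated half-life is 0.28 h with an expected range from 0.14 h to 0.52 h in this measurement.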

Compound 4, half-life: 0.3 h
Compound 4: middle estimate off by 1.1-fold (0.03 log units), on the low side; measured number inside the range.
By their numbers in this assay, from the lowest: compounds 1, 2, 4 and 3 (each within the scatter of the next).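

In this assay, putting methyl in place of hydrogen on this aromatic carbon, meta to a chloro group, gives a 1.1-fold higher number from compound 2 to compound 4 (0.03 log units; within the scatter) and so brings no change that can be told from the scatter. For the compounds shown here, the earlier steps altered other carbons, which makes this the first direct reading at this position: here, a single added carbon leaves the half-life indistinguishable from that of compound 2. Nothing available explains this result.

With only hydrogen and methyl shown on this carbon, one small group says little about the position as a whole, and what a longer chain such as propyl, an amine or a carboxylic acid would do there stays open. Also open, going by these compounds, is whether methyl here would read the same without the chloro group.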